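The compounds below may be only part of what the source reports. "The series", "measured", "known", "first", "only" and "open" are said of these compounds alone.

Measured in a functional assay (plasma) with Oryctolagus cuniculus as the target; on this read-out higher numbers stand for weaker inhibition and lower numbers for stronger inhibition:
- compound 1 `COC(=O)NC(CC(=O)N1CCC(Cn2c(C)nc3cnccc32)CC1)c1ccccc1` gives 12 nM
- compound 2 `Cc1nc2cnccc2n1CC1CCN(C(=O)N[C@@H](C)c2ccccc2)CC1` gives 41 nM
- compound 3 `Cc1nc2cnccc2n1CC1CCN(C(=O)NC2(c3ccccc3)CC2)CC1` gives 17 nM

Compound 1 has a number within the scatter of that of compound 3 and clearly lower than that of compound 2, so it stands among the stronger inhibitors of this small set.

Compound 4 `CCOC(=O)C(CC(=O)N1CCC(Cn2c(C)nc3cnccc32)CC1)c1ccccc1` carries ethoxycarbonyl in place of (methoxycarbonyl)amino on a saturated chain carbon bound to an aromatic carbon and a saturated chain carbon.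

Among the compounds with values here, no measured step touches this place. The only one, a 2.4-fold lower number from compound 2 to compound 3 (0.38 log units; beyond the scatter), exchanges 1-phenylethyl for 1-phenylcyclopropyl on an amide-type nitrogen elsewhere in the series, so it offers only a rough guide to size and none to direction. A modest move toward a higher number is expected, of about the size seen in that step, though the data cannot exclude no change. The expected step is a 2.5-fold higher number from compound 1 to compound 4 (0.40 log units; beyond the scatter). The estimate for compound 4 is 30 nM, with an expected range from 9 nM to 100 nM.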

Compound 4, half-maximal inhibitory concentration: 12 nM
The estimate for compound 4 lay 2.5-fold (0.40 log units) above the measured number, within the range that was stated.
By their numbers in this assay, from the lowest: compounds 1, 4 and 3 (each within the scatter of the next); then compound 2.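

In this assay, putting ethoxycarbonyl in place of (methoxycarbonyl)amino on a saturated chain carbon bound to an aromatic carbon and a saturated chain carbon gives no change at the digits printed from compound 1 to compound 4 (within the scatter). At this place, then, the read-out does not depend on the nitrogen or on the hydrogen-bond donor of the group that leaves: the entering group has 0 hydrogen-bond donors against 1, with 5 heavy atoms and 2 hydrogen-bond acceptors in both, and compound 1 and compound 4 cannot be told apart. Nothing available explains why this exchange leaves the number as it is.

The compounds shown leave open whether a carboxylic acid, an amine or a longer ester such as butoxycarbonyl would be accepted at this place as well. They also leave open whether the place accepts a plain hydrogen, with no substituent on this chain carbon at all.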